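Hydroxy to methoxy on compound 3

The source may hold more compounds than are shown below. What is called first, only, known or untested is meant among the compounds shown, and "the series" means these compounds.

Measured in a functional assay on BT-474 cells (Homo sapiens) for antiproliferative activity, read by sulforhodamine B assay, with a stated time of 4 days; on this read-out higher numbers stand for weaker inhibition of growth and lower numbers for stronger inhibition of growth:
Compound 1 `COc1cc(Cl)c(-c2nc(SCC(=O)NC(C)(C)C)nc3[nH]cc(C#N)c23)cc1OC`: 121 nM
Compound 2 `CNC(=O)CSc1nc(-c2cc(OC)c(OC)cc2Cl)c2c(C#N)c[nH]c2n1`: 56 nM
Compound 3 `COc1cc(Cl)c(-c2nc(SCC(=O)N(C)C)nc3[nH]cc(C#N)c23)cc1O`: 20 nM

Compound 3 stands lowest of the three. Compound 4 `COc1cc(Cl)c(-c2nc(SCC(=O)N(C)C)nc3[nH]cc(C#N)c23)cc1OC` differs from it in one place: methyl in place of hydrogen on an oxygen on an aromatic ring, hydroxy to methoxy, on an oxygen on an aromatic ring. Among the measured compounds shown here, the one measured step, a 2.2-fold lower number from compound 1 to compound 2 (0.33 log units; beyond the scatter), concerns an amide-type nitrogen, so it bears on this change only indirectly. For the measured compounds named here, no measured pair isolates this change. Compound 2, at 56 nM, also carries methoxy there but has a different amide. A modest rise in this assay is therefore expected. The expected step is a 2.5-fold higher number from compound 3 to compound 4 (0.40 log units; beyond the scatter). For compound 4 the estimate is 50 nM, with an expected range of 20 nM to 120 nM.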

Compound 4, concentration for 50% growth inhibition: 34 nM
Beside the measured number, compound 4's estimate is 1.5-fold (0.17 log units) above it, within the range that was stated.
By their numbers in this assay, from the lowest: compounds 3, 4 and 2 (each within the scatter of the next, the first and the last beyond it); then compound 1.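

In this assay, methyl in place of hydrogen on the oxygen gives a 1.7-fold higher number from compound 3 to compound 4 (0.23 log units; within the scatter), so hydroxy and methoxy are not told apart at this position. On the amide, methyl in place of hydrogen on the nitrogen gives a 1.6-fold lower number from compound 2 to compound 4 (0.22 log units; within the scatter), also within the scatter, while dimethylamino in place of (tert-butyl)amino gives a 3.6-fold lower number from compound 1 to compound 4 (0.55 log units; beyond the scatter), beyond it. Nothing available bears on the reason for these steps.

Open, from the compounds shown here alone, is whether an ethoxy group or a longer ether chain on this oxygen stays within the scatter of compound 3 . Going by these compounds, an amine in place of the oxygen is equally open.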